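This account rests on a few compounds, and the source may have more. Where it says the series, first, only, none or still open, it means among the compounds named here.

Measured in an ADME assay on MT4 cells (Homo sapiens) for cytotoxicity, read by MTT assay, with a stated time of 3 days; a higher number here means that more compound is tolerated, a lower number that less compound is tolerated:
Compound 1 `O=C(COC(=O)c1ccc([N+](=O)[O-])o1)NC1CCc2ccccc21`: > 100000 nM
Compound 2 `CC(=O)Oc1ccc(CN(C(=O)COC(=O)c2ccc([N+](=O)[O-])o2)C(C)(C)C)cc1`: > 100000 nM
Compound 3 `CC(=O)Oc1ccccc1CN(C(=O)COC(=O)c1ccc([N+](=O)[O-])o1)C(C)(C)C`: > 100000 nM

Each of these entries is a limit of the assay and not a number, and together they make up (the limit of > 100000 nM in this assay, at which 3 of the 3 values shown sit). Compound 3 stands at > 100000 nM, which is a limit.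

Compound 4 `CC(C)(C)N(Cc1ccc(C(F)(F)F)cc1)C(=O)COC(=O)c1ccc([N+](=O)[O-])o1` has 4-(trifluoromethyl)phenyl in place of 2-acetoxyphenyl on a saturated chain carbon bound to an amide-type nitrogen. Within the data shown here, the one measured step at this place is a step that the two limits leave unreadable from compound 2 to compound 3, so it offers no size to carry over. Among the measured compounds shown here, no measured compound carries the 4-(trifluoromethyl)phenyl group, and no direction can be read from the data. In this assay, compound 4 is therefore expected to stay close to the limit, with no change beyond the scatter, although a reading just under the limit remains possible. The expected change is an at least 1.2-fold lower number from compound 3 to compound 4 (0.09 log units; that floor lies within the scatter). For compound 4 the estimated value is 80000 nM, with an expected range from 25000 nM to 100000 nM.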

Compound 4, half-maximal cytotoxic concentration: 71000 nM
Estimate against measurement, compound 4: 1.1-fold (0.05 log units) above; the range from low to high includes it.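

In this assay compound 4 is the only compound shown that gives a number instead of a limit, so this position now has a reading inside the range of the assay. Setting 4-(trifluoromethyl)phenyl in place of 2-acetoxyphenyl on a saturated chain carbon bound to an amide-type nitrogen gives an at least 1.4-fold lower number from compound 3 to compound 4 (0.14 log units; that floor lies within the scatter), and trifluoromethyl in place of acetoxy on an aromatic carbon gives an at least 1.4-fold lower number from compound 2 to compound 4 (0.14 log units; that floor lies within the scatter). Both floors lie within the scatter, so neither step establishes a real change, and the other compounds remain at the edge of the assay: the limit of > 100000 nM in this assay, at which 3 of the 4 values shown sit.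

From the compounds shown here alone, the true size of either step stays open while compounds 2 and 3 are limits. Going by these compounds, it is also open whether an amine or a carboxylic acid in place of trifluoromethyl on that aromatic carbon would keep the reading under the limit.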